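Compound 3 to compound 4: one added chloro

The compounds below may be only part of what the source reports. "The series", "measured", "known", "first", "only" and "open" are said of these compounds alone.

Values from a functional assay on IGROV-1 cells (Homo sapiens) for inhibition, read by sulforhodamine B assay, with a stated time of 48 h (on this read-out lower numbers stand for stronger inhibition of growth and higher numbers for weaker inhibition of growth), follow
compound 1 `Cc1ccc(NC(=O)/C=C/c2ccccc2)c(C(N)=O)c1` gives 4370 nM
compound 2 `NC(=O)c1cc(Br)ccc1NC(=O)/C=C/c1ccccc1` gives 1020000 nM
compound 3 `NC(=O)c1cc(I)ccc1NC(=O)/C=C/c1ccccc1` gives 917 nM

Compound 3 has the lowest number of the three at 917 nM, and its steps to both other compounds lie beyond the scatter. Compound 4 `NC(=O)c1cc(I)ccc1NC(=O)/C=C/c1ccccc1Cl` keeps the iodo group of compound 3 but turns the phenyl into 2-chlorophenyl, with chloro in place of hydrogen on an aromatic carbon.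

Going by the values given here, no measured step makes this change, since all three swap a different group at a different place. They show only how far the number can move among these compounds. Iodo in place of methyl gave a 4.8-fold lower number from compound 1 to compound 3 (0.68 log units; beyond the scatter), a modest move. Bromo in place of methyl gave a 230-fold higher number from compound 1 to compound 2 (2.37 log units; beyond the scatter), and iodo in place of bromo gave a 1100-fold lower number from compound 2 to compound 3 (3.05 log units; beyond the scatter), both large moves.

These steps give no direction for the added chloro, so a small change in this assay is the central guess, with a wide margin on both sides. The expected step is a 1.1-fold lower number from compound 3 to compound 4 (0.06 log units; within the scatter). For compound 4 the estimated value is 800 nM, with an expected range from 150 nM to 5000 nM.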

Compound 4, concentration for 50% growth inhibition: 352 nM
The estimate for compound 4 lay 2.3-fold (0.36 log units) above the measured number; measured number inside the range.
By their numbers in this assay, from the lowest: compound 4; then compound 3; then compound 1; then compound 2.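

In this assay, the change from phenyl to 2-chlorophenyl gives a 2.6-fold lower number from compound 3 to compound 4 (0.42 log units; beyond the scatter) with the iodo group kept in place, a modest move that still lies beyond the scatter. Going by these compounds alone, the earlier steps all swapped one group at a single other place, so this is the first sign that the number also responds to a change on the phenyl, here on an aromatic carbon ortho to a large group. Compound 4 now has the lowest number of the four compounds, but nothing available explains why this one added chlorine lowers the number.

The compounds shown leave open whether the same chloro would lower the number with the methyl of compound 1 or the bromo of compound 2 in place of the iodo group, since this change is seen only alongside iodo. They also leave open whether the gain belongs to chloro itself or would appear with another group at this place, such as fluoro, methoxy or an amine, or with chloro on a different carbon of the phenyl.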